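This account rests on a few compounds, and the source may have more. Where it says the series, first, only, none or still open, it means among the compounds named here.

Measured in a functional assay on HeLa cells (Homo sapiens) for cytotoxicity, read by MTT assay, with a stated time of 48 h; on this read-out lower numbers stand for stronger inhibition and higher numbers for weaker inhibition:
- compound 1 `COc1ccc(/C=C/c2cc(OC)c(OC)c(OC)c2-c2ccc(OC)cc2)cc1`: 19000 nM
- compound 2 `COc1ccc(/C=C/c2cc(OC)c(OC)c(OC)c2-c2ccccc2)cc1`: 26000 nM
- compound 3 `C=C(c1ccc(OC)cc1)c1cc(OC)c(OC)c(OC)c1-c1ccc(OC)cc1`: 72000 nM

Among the compounds with values here, of these three numbers, the one for compound 3 is the highest, so it stands at the weak end of the small set. Compound 4 `C=C(c1ccc(OC)cc1)c1cc(OC)c(OC)c(OC)c1-c1ccccc1` has not yet been measured. It differs from compound 3 in one place: hydrogen in place of methoxy on an aromatic carbon. This is hydrogen in place of methoxy on an aromatic carbon, para to a large group, so that 4-methoxyphenyl becomes phenyl.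

One measured step makes the same exchange: a 1.4-fold higher number from compound 1 to compound 2 (0.14 log units; within the scatter). That step lies within the scatter. The other measured step, a 3.8-fold higher number from compound 1 to compound 3 (0.58 log units; beyond the scatter), is the replacement of 2-(4-methoxyphenyl)ethenyl by 1-(4-methoxyphenyl)ethenyl. It sets the starting level of compound 3 but does not touch the exchanged methoxy. Within the data shown here, only a single pair therefore speaks to this exchange, and no measured pair shows it on the 1-(4-methoxyphenyl)ethenyl series. On that evidence, no step beyond the scatter is expected in this assay, with at most a slight drift towards a higher number. The estimated change is a 1.3-fold higher number from compound 3 to compound 4 (0.10 log units; within the scatter). For compound 4 the expected value is about 90000 nM, with an estimated range of 40000 nM to 190000 nM.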

Compound 4, half-maximal inhibitory concentration: 11000 nM
Beside the measured number, compound 4's estimate is 8.2-fold (0.91 log units) above it; measured number below the stated range.
By their numbers in this assay, from the lowest: compounds 4, 1 and 2 (each within the scatter of the next, the first and the last beyond it); then compound 3.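

In this assay the exchange of 4-methoxyphenyl for phenyl gives a 6.5-fold lower number from compound 3 to compound 4 (0.82 log units; beyond the scatter) and so, on the 1-(4-methoxyphenyl)ethenyl series, the methoxy at this place clearly matters. The two ethenyl groups also change order with this exchange: with the methoxy present, the step is a 3.8-fold higher number from compound 1 to compound 3 (0.58 log units; beyond the scatter) whereas, with phenyl in its place, compound 2 gives 26000 nM and compound 4 gives the lower number of 11000 nM in the same assay. The exchange therefore cannot be carried from one core to the other as a single fixed step: the same change on two cores in this assay, a 1.4-fold higher number (0.14 log units; within the scatter) from compound 1 to compound 2 and a 6.5-fold lower number (0.82 log units; beyond the scatter) from compound 3 to compound 4, 9.0-fold (0.95 log units) apart, beyond the scatter of two such steps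

The compounds shown leave open whether the lower number of compound 4 follows from the loss of the methoxy itself or would also appear with other groups at this place, such as a hydroxy, a fluorine or a longer ethoxy chain. Within the data shown here, with only hydrogen and methoxy compared here, and only two cores carrying them, they also leave open whether the exchange would follow compound 2 or compound 4 on any further core.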